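The source may hold more compounds than are shown below. What is called first, only, known or untested is meant among the compounds shown, and "the series" means these compounds.

Measured in a functional assay on MCF7 cells (Homo sapiens) for inhibition, read by MTT assay, with a stated time of 72 h; a lower number here means a stronger inhibitor, a higher number a weaker inhibitor:

Compound 1 `Cc1cc2occ(-c3nc(-c4ccccc4)c(-c4ccccc4)n3-c3ccc([N+](=O)[O-])cc3)c(=O)c2cc1Cl` gives 6250 nM
Compound 2 `Cc1cccc(-n2c(-c3coc4cc(C)c(Cl)cc4c3=O)nc(-c3ccccc3)c2-c2ccccc2)c1` gives 12500 nM
Compound 3 `Cc1cc2occ(-c3nc(-c4ccccc4)c(-c4ccccc4)n3-c3ccccc3Cl)c(=O)c2cc1Cl` gives 3120 nM

Compound 2 stands at the high, weaker end of these numbers, level within the scatter with compound 1 (a 2.0-fold higher number from compound 1 to compound 2 (0.30 log units; within the scatter)). Compound 3 lies clearly lower (a 4.0-fold lower number from compound 2 to compound 3 (0.60 log units; beyond the scatter)).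

Compound 4 `COc1cccc(-n2c(-c3coc4cc(C)c(Cl)cc4c3=O)nc(-c3ccccc3)c2-c2ccccc2)c1` has not yet been measured. It keeps the shared core of compound 2 but carries methoxy in place of methyl on an aromatic carbon, so that 3-methylphenyl becomes 3-methoxyphenyl (methoxy in place of methyl on an aromatic carbon).

For the measured compounds named here, no measured step makes this exact swap. The nearest evidence comes from changes to the whole aromatic group on the nitrogen. Compound 3 differs from compound 1 by only a 2.0-fold lower number from compound 1 to compound 3 (0.30 log units; within the scatter), and the largest such change, a 4.0-fold lower number from compound 2 to compound 3 (0.60 log units; beyond the scatter), is modest. A swap confined to one small group should therefore matter little in this assay.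

The expected change is a 1.6-fold lower number from compound 2 to compound 4 (0.19 log units; within the scatter), which is no step beyond the scatter. For compound 4 the estimated value is 8000 nM, with an expected range of 3000 nM to 20000 nM.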

Compound 4, half-maximal inhibitory concentration: 25000 nM
The estimate for compound 4 lay 3.1-fold (0.49 log units) below the measured number; measured number outside the range, above it.
By their numbers in this assay, from the lowest: compounds 3, 1, 2 and 4 (each within the scatter of the next, the first and the last beyond it).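

Swapping methyl for methoxy on an aromatic carbon, meta to a large group, gives the first direct reading at this position in this assay, and the step stays within the scatter (a 2.0-fold higher number from compound 2 to compound 4 (0.30 log units; within the scatter)). The 3-methoxyphenyl group still separates clearly from the other two groups on the nitrogen, with a weaker result against 2-chlorophenyl (an 8.0-fold higher number from compound 3 to compound 4 (0.90 log units; beyond the scatter)) and against 4-nitrophenyl (a 4.0-fold higher number from compound 1 to compound 4 (0.60 log units; beyond the scatter)). No measurement is available that would explain these differences.

Each aromatic group on the nitrogen carries a different substituent at a different place, so the effect of the group cannot be separated from the effect of its place. As far as these compounds go, whether a hydroxyl, an amine or a longer chain such as ethoxy at this position would shift the number remains open.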